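The compounds below may be only part of what the source reports. "The series", "measured", "known", "first", "only" and "open" are said of these compounds alone.

Working notes on the step to compound 4 `CC(C)=CCC[C@](C)(/C=C/c1ccc(O)cc1)/C=C/c1ccc(C#N)cc1`. In a functional assay on HepG2 cells (Homo sapiens) for cytotoxicity, with a stated time of 72 h (on this read-out higher numbers stand for an effect only at larger amounts of compound and lower numbers for an effect already at smaller amounts), compound 3 `CCOc1ccc(/C=C/[C@@](C)(/C=C/c2ccc(O)cc2)CCC=C(C)C)cc1` gives > 52000 nM, which is a limit and not a number. In this assay compound 2 `CCOC(=O)/C(C)=C/c1cc(/C=C/[C@](C)(/C=C/c2ccc(OC)cc2)CCC=C(C)C)ccc1O` gives > 52000 nM, also a limit. In this assay compound 1 `COc1ccc(/C=C/[C@@](C)(/C=C/c2ccc(O)c(C=O)c2)CCC=C(C)C)cc1` gives > 26000 nM, again a limit. Compound 3 therefore has no number to stand on, and neither of the other two compounds offers one for comparison.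

The change is cyano in place of ethoxy on an aromatic carbon, para to a large group: cyano in place of ethoxy on an aromatic carbon. For the measured compounds named here, the only measured step, a step that the two limits leave unreadable from compound 1 to compound 2, involves different groups and gives no size to carry over. No step beyond the scatter is therefore expected in this assay, and no direction can be assigned. This expectation rests on compound 3, whose > 52000 nM remains a limit. The expected step is an at least 1.1-fold lower number from compound 3 to compound 4 (0.06 log units; that floor lies within the scatter). For compound 4 the estimated value is 45000 nM, with an expected range of 20000 nM to 100000 nM. Another limit is the likelier report for compound 4.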

Compound 4, half-maximal effective concentration: > 52000 nM
Compound 4 gave a limit, no number (the forecaster's own chance of this, stated with the estimate: 75%); at least 1.1-fold (0.06 log units) between middle value and limit.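

In this assay, compound 3 and compound 4 both give limits and not numbers, so no step can be read between them. The compounds shown leave open whether cyano in place of ethoxy on an aromatic carbon shifts the cytotoxic concentration at all.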